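Moving the Ring Nitrogen: From Compound 3 to Compound 4

The source may report more compounds than this note shows. Statements on the series, on what has been measured and on what is new or still open speak of the compounds shown alone.

Measured compounds:
compound 1 `CN(C)c1ccc(/C=N/NC(=O)c2cccnc2Nc2cccc(C(F)(F)F)c2)cc1`: 61.3%
compound 2 `CNc1ncccc1C(=O)N/N=C/c1ccccc1`: 56.5%
compound 3 `CNc1ncccc1C(=O)N/N=C/c1cccnc1`: 66.3%

In a functional assay on the whole organism (strain Wistar) for inhibition, with Rattus norvegicus as the target, read by paw edema, with a stated time of 30 min, at a dose of 10 mg/kg by the intraperitoneal route (on this read-out lower numbers stand for less inhibition and higher numbers for more inhibition at the one dose given (going by the name of the read-out)), compound 3 gives the highest of the three numbers, yet its gaps to compound 1 and to compound 2 both lie within the usual scatter, so the three compounds cannot be ranked against each other on these figures. Compound 4 `CNc1ncccc1C(=O)N/N=C/c1ccncc1` differs from compound 3 by pyridin-4-yl in place of pyridin-3-yl on a carbon with a double bond to nitrogen. For the measured compounds named here, the only measured step touching this part of the molecule is a number 9.8 percentage points higher from compound 2 to compound 3 (within the scatter), which stayed within the scatter. Going by the values given here, no measured step moves the ring nitrogen from one position to another, so nothing measured speaks directly to the change at hand. On that basis no step beyond the scatter is expected in this assay, in either direction. Compound 4 is therefore estimated to give 64%, with a range from 52% to 76%, which amounts to an expected step of a number 2.3 percentage points lower from compound 3 to compound 4 (within the scatter).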

Compound 4, a percentage reported as inhibition, in the whole organism at one dose (the size of the read-out at that dose, not a potency): 63.2%
Estimate against measurement, compound 4: 0.8 percentage points above, and the stated range covers the measured number.
By their numbers in this assay, from the lowest: compounds 2, 1, 4 and 3 (each within the scatter of the next).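

In this assay, for the compounds shown here, moving the ring nitrogen gives a number 3.1 percentage points lower from compound 3 to compound 4 (within the scatter), the first measured step that shifts this nitrogen from one ring position to another. Replacing phenyl with pyridin-4-yl gives a number 6.7 percentage points higher from compound 2 to compound 4 (within the scatter), so on a carbon with a double bond to nitrogen, the phenyl, pyridin-3-yl and pyridin-4-yl compounds cannot be told apart at this single dose, whether or not the ring holds a nitrogen or where that nitrogen sits. Nothing available offers an explanation for how closely these numbers agree.

Still open, from the compounds shown here alone, is whether a different group on this carbon, such as pyridin-2-yl, a phenyl ring carrying a carboxylic acid, or a saturated piperidine ring, would give a step beyond the scatter. The compounds shown also leave open how a longer chain in place of the methyl on the amine would read.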